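Adding a Bromo Group to the Phenyl of Compound 1

The source may hold more compounds than are shown below. What is called first, only, known or untested is meant among the compounds shown, and "the series" means these compounds.

In an assay on membranes from brain for displacement of a labelled ligand from adenosine receptor A1 (Rattus norvegicus), read by scintillation counting, with a stated time of 90 min (on this read-out higher numbers stand for weaker inhibition and lower numbers for stronger inhibition), the three measured compounds stand as follows:
Compound 1 `O=C(CCc1ccccc1)Nc1nc2ccccc2c(=O)s1` gives 422 nM.
Compound 2 `COc1cccc(/C=C/CC(=O)Nc2nc3ccccc3c(=O)s2)c1` gives 11.2 nM.
Compound 3 `O=C(C/C=C/c1ccccc1)Nc1nc2ccccc2c(=O)s1` gives 53 nM.

Compound 1 has the highest number of the three, a weaker inhibitor than compound 3 and further still from compound 2. Within the data shown here, the only single-point step among the measured compounds is a 4.7-fold higher number from compound 2 to compound 3 (0.68 log units; beyond the scatter), and it concerns a methoxy group on a compound whose linker differs from that of compound 1, so it bears only loosely on the present question.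

Compound 4 `O=C(CCc1ccccc1Br)Nc1nc2ccccc2c(=O)s1` differs from compound 1 by bromo in place of hydrogen on an aromatic carbon. Among the measured compounds shown here, no measured pair shows a bromo group entering or leaving, so there is no direct precedent. Going by these compounds, the methoxy step above shows that a single aromatic substituent can shift the number modestly, but its direction for a bromo group is unknown. The expectation for compound 4 is therefore a step of about a 1.4-fold lower number from compound 1 to compound 4 (0.15 log units; within the scatter), at most modest and not clearly beyond the scatter. Compound 4 is estimated at 300 nM, within a range from 100 nM to 900 nM.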

Compound 4, inhibition constant: > 10000 nM
Compound 4: no number, only a limit; the forecaster's own chance of this, stated with the estimate: 3%; middle value at least 33-fold (1.52 log units) from the limit.
By their numbers in this assay, from the lowest: compound 2; then compound 3; then compound 1. At a limit, above all of these: compound 4.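

Bromo as the 2-bromophenyl group, ortho to a large group, gives an at least 23-fold higher number from compound 1 to compound 4 (1.37 log units; beyond the scatter) in this assay, so this single heavy atom at this place is enough for a large loss of inhibition. Among these compounds, the only earlier single-place change on an aromatic carbon, a 4.7-fold higher number from compound 2 to compound 3 (0.68 log units; beyond the scatter), was modest and sat on a different linker, so it gave no sign that one substituent could move the number this far. Compound 4 gives a limit and not a number: the limit of > 10000 nM in this assay, at which 1 of the 4 values shown sits.

The compounds shown leave open whether fluoro, chloro or methyl at this same place would give a step of this size, or whether bromo elsewhere on the phenyl ring would. They also leave open what bromo would do on the linker of compound 3.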